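The source may hold more compounds than are shown below. What is called first, only, known or untested is meant among the compounds shown, and "the series" means these compounds.

Series notes. In an assay on CHO-K1 cells for displacement of a labelled ligand from prostaglandin E2 receptor EP1 subtype (Homo sapiens) (on this read-out lower numbers stand for stronger inhibition and higher numbers for weaker inhibition), compound 1 `Cc1cc(C(=O)O)nn1Cc1cc(Br)ccc1OCc1ccccc1` gives 6.31 nM, compound 2 `Cc1cc(C(=O)NCc2cccnc2)nn1Cc1cc(Cl)ccc1OCc1ccccc1` gives 50.1 nM and compound 3 `Cc1cc(NC(=O)C2CCCC2)nn1Cc1cc(Cl)ccc1OCC(C)C` gives 25.1 nM. Compound 2 holds the highest of the three numbers; its gap to compound 3 lies within the scatter, its gap to compound 1 lies beyond it. Compound 4 `Cc1cc(NC(=O)O[C@H]2CCOC2)nn1Cc1cc(Cl)ccc1OCc1ccccc1` has not been measured in this assay. It differs from compound 2 in one place: (((oxolan-3-yl)oxy)carbonyl)amino in place of ((pyridin-3-yl)methyl)carbamoyl on an aromatic carbon. Going by the values given here, no measured pair shows this change, so only a guarded expectation follows. Compound 4 carries, like compound 3, a group joined through nitrogen at that ring carbon, and a modest drop in the number is expected for compound 4, about a 2.5-fold lower number from compound 2 to compound 4 (0.40 log units; beyond the scatter), because compound 3 gives 25.1 nM in this assay. The estimate for compound 4 is 20 nM, with a range from 5 nM to 80 nM.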

Compound 4, half-maximal inhibitory concentration: 79.4 nM
Estimate against measurement, compound 4: 4.0-fold (0.60 log units) below; the range from low to high includes it.
By their numbers in this assay, from the lowest: compound 1; then compounds 3, 2 and 4 (each within the scatter of the next, the first and the last beyond it).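

At this aromatic carbon, next to the ring nitrogen, (((oxolan-3-yl)oxy)carbonyl)amino in place of ((pyridin-3-yl)methyl)carbamoyl gives a 1.6-fold higher number from compound 2 to compound 4 (0.20 log units; within the scatter) in this assay. Going by these compounds alone, this is the first single-place comparison at this position, and the two groups cannot be told apart on this read-out, even though one is joined through nitrogen and the other through a carbonyl. No measurement at hand accounts for this reading.

Still open, going by these compounds, is how a primary amine or a methyl ester would read at this carbon on the core of compound 2. On these data alone, the opposite configuration of the oxolan-3-yl stereocentre also remains open.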